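Methylsulfanyl for Bromo on a Rearranged Core

A few compounds are considered here, and "the series" means these few. Any claim that something is new, unique, unknown or untested is made for them only; others in the source may bear on it.

Three compounds have been measured in an ADME assay on MRC5 cells (Homo sapiens) for cytotoxicity, read by fluorescence, with a stated time of 72 h; on this read-out lower numbers stand for stronger inhibition and higher numbers for weaker inhibition:
compound 1 `CC1(COc2ccc(OC(F)(F)F)cc2)Cn2cc(Br)nc2O1` gives 34000 nM;
compound 2 `CSc1cn2c(n1)OC(C)(COc1ccc(OC(F)(F)F)cc1)C2` gives 38000 nM;
compound 3 `CC1(COc2ccc(OC(F)(F)F)cc2)Cn2c(Br)cnc2O1` gives 26000 nM.

Compound 2 differs from compound 1 by methylsulfanyl in place of bromo on an aromatic carbon, and this made a 1.1-fold higher number from compound 1 to compound 2 (0.05 log units; within the scatter). Compound 3 has the same atoms as compound 1 joined differently; the difference between the two cores is not broken down here. Compound 4 `CSc1cnc2n1CC(C)(COc1ccc(OC(F)(F)F)cc1)O2` is not yet measured and differs from compound 3 by methylsulfanyl in place of bromo on an aromatic carbon. This is the same kind of change, not the same: in compound 1 the carbon is two ring bonds from two ring atoms that each bear a fused ring, whereas in compound 3 it is next to the ring atom that bears a fused ring. Compound 4 is expected to show a 1.1-fold higher number from compound 3 to compound 4 (0.05 log units; within the scatter) in this assay because a 1.1-fold higher number from compound 1 to compound 2 (0.05 log units; within the scatter) was so small. The estimate for compound 4 is 29000 nM, between 15000 nM and 58000 nM.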

Compound 4, half-maximal inhibitory concentration: 25000 nM
For compound 4 the middle estimate is 1.2-fold (0.06 log units) above the measured one, and the stated range covers the measured number.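

On a second core, methylsulfanyl in place of bromo gives a 1.0-fold lower number from compound 3 to compound 4 (0.02 log units; within the scatter) in this assay. Set side by side, the two steps agree: the same change on two cores in this assay, a 1.1-fold higher number (0.05 log units; within the scatter) from compound 1 to compound 2 and a 1.0-fold lower number (0.02 log units; within the scatter) from compound 3 to compound 4, 1.2-fold (0.07 log units) apart, within the scatter of two such steps. This shows that, on these two cores, the swap made no difference that stands out from the scatter, but it does not show that the swap would behave the same way on any other core, and two steps this small cannot show that a sizeable effect carries across.

The compounds shown leave open whether a different group on this aromatic carbon, such as an amine, a carboxylic acid or a longer chain, would give a step beyond the scatter. They also leave open whether any such step would match on both cores.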